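This account rests on a few compounds, and the source may have more. Where it says the series, first, only, none or still open, it means among the compounds named here.

In an ADME assay on MT4 cells (Homo sapiens) for cytotoxicity, read by MTT assay (a lower number here means that less compound is tolerated, a higher number that more compound is tolerated), compound 2 `Cc1cc(C)cc(S(=O)(=O)c2c(C(=O)NC(C)C(=O)NCc3ccncn3)[nH]c3ccc(Cl)cc23)c1` gives 28100 nM and compound 1 `Cc1cc(C)cc(S(=O)(=O)c2c(C(=O)NC(C)C(=O)NC(C)c3ccccc3F)[nH]c3ccc(Cl)cc23)c1` gives 15200 nM, so the two cannot be told apart. Compound 3 `Cc1cc(C)cc(S(=O)(=O)c2c(C(=O)NC(C)C(=O)NCc3ccccc3F)[nH]c3ccc(Cl)cc23)c1` differs from compound 2 in one place: 2-fluorophenyl in place of pyrimidin-4-yl on a saturated chain carbon bound to an amide-type nitrogen. Going by the values given here, the one measured step that bears on this is a 1.8-fold higher number from compound 1 to compound 2 (0.27 log units; within the scatter), where (pyrimidin-4-yl)methyl took the place of 1-(2-fluorophenyl)ethyl, a group that also carries 2-fluorophenyl. Run backwards, that step points to a small change, so the expected step is a 1.5-fold lower number from compound 2 to compound 3 (0.17 log units; within the scatter), with none expected beyond the scatter in this assay. For compound 3 the estimated value is 19000 nM, with an expected range of 9500 nM to 38000 nM.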

Compound 3, half-maximal cytotoxic concentration: 23300 nM
Beside the measured number, compound 3's estimate is 1.2-fold (0.09 log units) below it; measured number inside the range.
By their numbers in this assay, from the lowest: compounds 1, 3 and 2 (each within the scatter of the next).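

In this assay, exchanging the ring alone gives a small step (a 1.2-fold lower number from compound 2 to compound 3 (0.08 log units; within the scatter)), so pyrimidin-4-yl and 2-fluorophenyl cannot be told apart here, despite their different hetero atoms and hydrogen-bond acceptors. Hydrogen in place of methyl, taken alone, also stays small (a 1.5-fold higher number from compound 1 to compound 3 (0.19 log units; within the scatter)), whereas the earlier step changed ring and methyl together. No measured evidence accounts for these numbers. Still open, going by these compounds, is whether an amine or a carboxylic acid in place of the ring, or a longer chain in place of that methyl, would move the number beyond the scatter.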